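From arylsulfanyl to methylsulfanyl on the shared core

This account rests on a few compounds, and the source may have more. Where it says the series, first, only, none or still open, it means among the compounds named here.

In a functional assay on MCF7 cells (Homo sapiens) for antiproliferative activity, read by sulforhodamine B assay, with a stated time of 3 days (a lower number here means a stronger inhibitor, a higher number a weaker inhibitor), compound 1 `c1ccc(Oc2ncnc3ncn(C4COc5ccccc5CO4)c23)cc1` gives 21100 nM, compound 2 `c1ccc(Sc2ncnc3ncn(C4COc5ccccc5CO4)c23)cc1` gives 15600 nM and compound 3 `Fc1ccc(Sc2ncnc3ncn(C4COc5ccccc5CO4)c23)cc1` gives 14100 nM. These three values lie within the scatter of one another, so compound 3 cannot be set apart from the other two. Compound 4 `CSc1ncnc2ncn(C3COc4ccccc4CO3)c12` keeps the core of compound 3 and carries methyl in place of 4-fluorophenyl on a sulfur.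

The closest evidence is a 1.1-fold lower number from compound 2 to compound 3 (0.04 log units; within the scatter), alongside the exchanges of phenoxy for the sulfanyl groups, a 1.4-fold lower number from compound 1 to compound 2 (0.13 log units; within the scatter) and a 1.5-fold lower number from compound 1 to compound 3 (0.18 log units; within the scatter). All three lie within the scatter. None of them removes the aromatic ring from the sulfur, so the change to compound 4 goes beyond anything measured and the data give it no firm direction. No step beyond the scatter is therefore expected in this assay, though with wide uncertainty. The estimated step is a 1.4-fold higher number from compound 3 to compound 4 (0.15 log units; within the scatter). For compound 4 the estimated value is 20000 nM, with an expected range of 8000 nM to 50000 nM.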

Compound 4, half-maximal inhibitory concentration: 31800 nM
For compound 4 the middle estimate is 1.6-fold (0.20 log units) below the measured one, within the range that was stated.
By their numbers in this assay, from the lowest: compounds 3, 2, 1 and 4 (each within the scatter of the next, the first and the last beyond it).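

Going by these compounds alone, on a sulfur at this place, the aromatic ring now proves to matter in this assay: methyl in place of an aryl group gives the first steps beyond the scatter, both modest (a 2.3-fold higher number from compound 3 to compound 4 (0.35 log units; beyond the scatter) and a 2.0-fold higher number from compound 2 to compound 4 (0.31 log units; beyond the scatter)). The phenoxy compound does not share this separation, since methylsulfanyl in place of phenoxy stays within the scatter (a 1.5-fold higher number from compound 1 to compound 4 (0.18 log units; within the scatter)), so the effect of losing the ring is seen only against the arylsulfanyl compounds, and all four values remain weak and close together. Nothing measured here accounts for the difference between methyl and the aryl groups on sulfur.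

The compounds shown leave open whether a longer chain on the sulfur, such as butyl, would stand with methyl or with the aryl groups. They also leave open how an amine on this aromatic carbon, in place of the sulfur or oxygen link, would compare.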